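This account rests on a few compounds, and the source may have more. Where it says the series, first, only, none or still open, it means among the compounds named here.

Measured so far:
compound 1, `COc1ccc2c(c1OC)C(=O)N(Cc1cc(Cl)ccc1NC(=O)c1ccccn1)C2=O`, gives > 100000 nM
compound 2, `O=C(Nc1ccc(Cl)cc1CN1C(=O)c2ccc(F)cc2C1=O)c1ccccn1`, gives 330 nM
compound 3, `O=C(Nc1ccc(Cl)cc1CN1C(=O)c2ccccc2C1=O)c1cccnn1`, gives > 100000 nM

All three were tested in an assay on CHO cells for positive allosteric modulation of metabotropic glutamate receptor 5 (Homo sapiens), read by FLIPR; a higher number here means that more compound is needed for the effect, a lower number that less compound is needed. For compound 1 the value > 100000 nM is a limit of the assay, not a measured number. For compound 3 the value > 100000 nM is likewise only a limit, so compound 3 stands at the edge of what the assay can report, at the limit of > 100000 nM in this assay, at which 2 of the 3 values shown sit. Compound 2 gives 330 nM as a true number. For the measured compounds named here, no step between two measured compounds that differ in a single place is available, so the pair of compound 2 and compound 3 shows only that one has a number and the other a limit.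

Compound 4, `O=C(Nc1ccc(Cl)cc1CN1C(=O)c2ccccc2C1=O)c1ncccc1O`, has not yet been measured in this assay. It differs from compound 3 in one place: 3-hydroxypyridin-2-yl in place of pyridazin-3-yl on a carbonyl carbon. The expectation for compound 4 rests on compound 2, whose 330 nM shows that a closely related amide on the same kind of core can give a measured number. The step of an at least 66-fold lower number from compound 3 to compound 4 (1.82 log units; beyond the scatter) is expected to run downward, from a limit to a number, although a second limit remains a real possibility. Compound 4 is estimated at 1500 nM, with a range from 200 nM to 30000 nM.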

Compound 4, half-maximal effective concentration: 260 nM
Beside the measured number, compound 4's estimate is 5.8-fold (0.76 log units) above it; the range from low to high includes it.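

On this carbonyl carbon, with the rest of the molecule unchanged, 3-hydroxypyridin-2-yl in place of pyridazin-3-yl gives an at least 380-fold lower number from compound 3 to compound 4 (2.58 log units; beyond the scatter) in this assay. For the compounds shown here, this is the first change in a single place that can be read here, and it shows that the group on this carbonyl carbon alone can decide whether a compound on this core reaches a measurable number. The value for compound 3 is a limit and not a number, so the step gives only the smallest size the change can have: the limit of > 100000 nM in this assay, at which 2 of the 4 values shown sit.

Going by these compounds, it remains open whether the hydroxy group or the change to a ring with one hetero atom carries the step, which a plain pyridin-2-yl on this same core would help to separate. Also open, on these data alone, is how an amine or a carboxylic acid in place of the hydroxy group would read in this assay.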